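A Third Halophenyl Variant Tested on Histone Deacetylase 8

The source may report more compounds than this note shows. Statements on the series, on what has been measured and on what is new or still open speak of the compounds shown alone.

Compound 1 `O=C1NC(=O)/C(=C\c2ccc(OCC(=O)N3N=C(c4ccccc4)CC3c3ccc(F)cc3F)cc2)S1`: 34000 nM
Compound 2 `O=C1NC(=O)/C(=C\c2ccc(OCC(=O)N3N=C(c4ccccc4)CC3c3ccc(Cl)c(Cl)c3)cc2)S1`: 10000 nM

In an assay on cells for inhibition of histone deacetylase 8 (Homo sapiens), read by fluorescence, with a stated time of 30 min (on this read-out lower numbers stand for stronger inhibition and higher numbers for weaker inhibition), compound 2 holds the lower of the two numbers, reached by the step of a 3.4-fold lower number from compound 1 to compound 2 (0.53 log units; beyond the scatter). Compound 3 `O=C1NC(=O)/C(=C\c2ccc(OCC(=O)N3N=C(c4ccccc4)CC3c3ccc(Br)cc3)cc2)S1` is the next variant: 4-bromophenyl in place of 3,4-dichlorophenyl on a saturated ring carbon. Going by the values given here, the only measured step that bears on this change is a 3.4-fold lower number from compound 1 to compound 2 (0.53 log units; beyond the scatter), which was modest and concerned a different halogen pattern on the same phenyl, so it guides the expectation only loosely. A step of modest size, most likely toward a somewhat higher number, is expected. Compound 3 is estimated at 18000 nM, within 6000 nM to 50000 nM. That estimate means an expected 1.8-fold higher number from compound 2 to compound 3 (0.26 log units; within the scatter).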

Compound 3, half-maximal inhibitory concentration: 35000 nM
The estimate for compound 3 lay 1.9-fold (0.29 log units) below the measured number; measured number inside the range.
By their numbers in this assay, from the lowest: compound 2; then compounds 1 and 3 (each within the scatter of the next).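

In this assay the change from 3,4-dichlorophenyl to 4-bromophenyl on the saturated ring carbon gives a 3.5-fold higher number from compound 2 to compound 3 (0.54 log units; beyond the scatter) and so reverses the earlier gain, while the comparison with 2,4-difluorophenyl gives a 1.0-fold higher number from compound 1 to compound 3 (0.01 log units; within the scatter) and places those two groups level within the scatter. Of the three halophenyl groups, only the 3,4-dichlorophenyl of compound 2 stands apart, with the lowest number. No evidence at hand accounts for this. Still open, as far as these compounds go, is how a phenyl ring carrying an amine or a methoxy group would read at this position, and whether any group here could reach a much lower number.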